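This account rests on a few compounds, and the source may have more. Where it says the series, first, only, none or still open, it means among the compounds named here.

Working notes on the series.

Compound 1 `Oc1cncc(N2CCCNCC2)c1` is the reference point. Within the data shown here, in a functional assay on HEK293 cells for agonist activity at Neuronal acetylcholine receptor; alpha4/beta2 (Homo sapiens), read by FLIPR and calcium flux (a higher number here means that more compound is needed for the effect, a lower number that less compound is needed), compound 1 gives 141 nM, the lowest of the three numbers measured so far. Compound 2 `Oc1cc(N2CCCNCC2)cnc1I` carries iodo in place of hydrogen on an aromatic carbon and gives 479 nM in this assay; the step is a 3.4-fold higher number from compound 1 to compound 2 (0.53 log units; beyond the scatter). Compound 3 `Brc1ccc(N2CCNCC2)cn1`, which shares no single-point relation with the others, gives 2510 nM in this assay, the furthest of the three from compound 1.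

Compound 4 `C=COc1cncc(N2CCCNCC2)c1` is not yet measured. It differs from compound 1 by vinyl in place of hydrogen on an oxygen on an aromatic ring; read one bond further out, the hydroxy becomes vinyloxy.

Among the measured compounds shown here, no measured step touches the oxygen on the aromatic ring, so nothing in hand speaks directly to this change. For the measured compounds named here, the only single-point step in the set is from compound 1 to compound 2, and it shows that a change on the core of compound 1 can move this assay by a modest amount. Capping the hydroxy is taken as likely to move the number in the same direction, with wide uncertainty. Compound 4 is therefore expected at about 400 nM, with a range of 120 nM to 1500 nM. That estimate corresponds to an expected step of a 2.8-fold higher number from compound 1 to compound 4 (0.45 log units; beyond the scatter).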

Compound 4, half-maximal effective concentration: 1100 nM
Beside the measured number, compound 4's estimate is 2.8-fold (0.44 log units) below it; low and high end bracket the measured number.
By their numbers in this assay, from the lowest: compound 1; then compound 2; then compound 4; then compound 3.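

Among these compounds, this is the first measured step at the oxygen on an aromatic ring. In this assay, vinyl in place of hydrogen there gives a 7.8-fold higher number from compound 1 to compound 4 (0.89 log units; beyond the scatter) and so shows that the number is sensitive to the change from hydroxy to vinyloxy, which earlier compounds left untested. Among the compounds shown here, its direction matches that of a 3.4-fold higher number from compound 1 to compound 2 (0.53 log units; beyond the scatter) at an aromatic carbon, so both single-point changes to the core of compound 1 raise the number, with no measured step against this, although two steps are a thin basis for any pattern. Nothing in hand explains the size of the new step or separates the loss of the hydrogen from the presence of the vinyl.

On these data alone, it remains open whether a methyl or ethyl group on the same oxygen would give a step of similar size, or whether the double bond of the vinyl has any bearing on the number. An amine or a fluorine in place of the whole hydroxy would also show whether the oxygen itself matters here, and how either would read in this assay cannot be told from the compounds shown.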